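Compound 3 to compound 4: longer chain, added cyclopropyl

A few compounds are considered here, and "the series" means these few. Any claim that something is new, unique, unknown or untested is made for them only; others in the source may bear on it.

In an ADME assay on microsomes from liver (Mus musculus) for metabolic stability, read by LC-MS, with a stated time of 10 min, tested at 0.5 uM (on this read-out higher numbers stand for a more stable compound and lower numbers for a less stable compound), compound 3 (`c1ccc2c(c1)CN[C@@H](CN(CCN1CCNCC1)[C@H]1CCCc3cccnc31)C2`) gives 79% and stands second of three numbers. The highest number comes from compound 1 (`c1ccc2c(c1)CN[C@@H](CN(CCCN1CCNCC1)[C@H]1CCCc3cccnc31)C2`) with 92%. The lowest comes from compound 2 (`c1ccc2c(c1)CN[C@@H](CN(CCC1CCNCC1)[C@H]1CCCc3cccnc31)C2`) with 32%.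

The change to compound 4 (`c1ccc2c(c1)CN[C@@H](CN(CCCN1CCN(C3CC3)CC1)[C@H]1CCCc3cccnc31)C2`) reads (4-cyclopropylpiperazin-1-yl)methyl in place of piperazin-1-yl on a saturated chain carbon, two bonds along the chain from an amine nitrogen and puts (4-cyclopropylpiperazin-1-yl)methyl in place of piperazin-1-yl on a saturated chain carbon, two bonds along the chain from an amine nitrogen.

The nearest measured step, a number 13 percentage points lower from compound 1 to compound 3 (beyond the scatter) as a modest one, runs from (piperazin-1-yl)methyl to piperazin-1-yl, so reversing it points upward for compound 4. Among the compounds with values here, no measured compound carries the cyclopropyl ring, and the estimate assumes that this addition offsets the rise. The large steps of a number 60 percentage points lower from compound 1 to compound 2 (beyond the scatter) and a number 47 percentage points higher from compound 2 to compound 3 (beyond the scatter) show that this place can move the number far, which widens the range.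

The estimated change is a number 7 percentage points lower from compound 3 to compound 4 (within the scatter) in this assay and no step beyond the scatter is expected. For compound 4 the estimate is 72% (expected range 45% to 92%).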

Compound 4, percent of the compound remaining: 3%
For compound 4 the middle estimate is 69 percentage points above the measured one; the whole stated range lies above it.
By their numbers in this assay, from the lowest: compound 4; then compound 2; then compound 3; then compound 1.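

Within the data shown here, with cyclopropyl as the single change on the shared scaffold, this assay reads a number 89 percentage points lower from compound 1 to compound 4 (beyond the scatter) and shows that substitution on the amine nitrogen in the piperazine ring can matter as much as anything varied on the chain so far. The same group also gives a number 76 percentage points lower from compound 3 to compound 4 (beyond the scatter) and a number 29 percentage points lower from compound 2 to compound 4 (beyond the scatter) in this assay, so (4-cyclopropylpiperazin-1-yl)methyl falls under piperidin-4-yl, which had held the lowest number at this place. Nothing available gives a reason for this loss of stability.

On these data alone, whether the loss belongs to cyclopropyl itself or extends to any group on that nitrogen, such as methyl, acetyl or oxetanyl, stays open. Also open, as far as these compounds go, is how cyclopropyl behaves on the shorter chain of compound 3.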